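Thiophen-2-yl for Cyclohexyl: Cytotoxicity Expected at the Limit

A few compounds are considered here, and "the series" means these few. Any claim that something is new, unique, unknown or untested is made for them only; others in the source may bear on it.

Measured compounds:
compound 1, `O=C(NCc1cccs1)c1cccc(O)c1O`, in an ADME assay on NCI-H630 cells (Homo sapiens) for cytotoxicity, read by MTT assay, with a stated time of 72 h (on this read-out higher numbers stand for lower toxicity in this test and lower numbers for higher toxicity in this test), gives > 40000 nM, a limit of the assay.
compound 2, `O=C(NCC1CCCCC1)c1cccc(O)c1O`, in this assay gives 21000 nM.
compound 3, `O=C(NCC1CCCCC1)c1cc(S(=O)(=O)N2CCCCC2)cc(O)c1O`, in this assay gives > 40000 nM, a limit of the assay.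

Compound 2 and compound 1 share a core and differ only where (thiophen-2-yl in place of cyclohexyl on a saturated chain carbon bound to an amide-type nitrogen). In this assay that change made an at least 1.9-fold higher number from compound 2 to compound 1 (0.27 log units; that floor lies within the scatter). Compound 3 differs from compound 2 in its core, where ((piperidin-1-yl)sulfonyl in place of hydrogen on an aromatic carbon), and that change made an at least 1.9-fold higher number from compound 2 to compound 3 (0.27 log units; that floor lies within the scatter). Both of these steps end at a limit; the limit of > 40000 nM in this assay, at which 2 of the 3 values shown sit, records this, and so neither step has a known upper size.

Compound 4, `O=C(NCc1cccs1)c1cc(S(=O)(=O)N2CCCCC2)cc(O)c1O`, is not yet measured. Going by the values given here, it differs from compound 3 where (thiophen-2-yl in place of cyclohexyl on a saturated chain carbon bound to an amide-type nitrogen), which is the same change as the one from compound 2 to compound 1, at a place described in the same words.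

For compound 4 in this assay the expected value is 60000 nM, with a range of 30000 nM to 150000 nM, because compound 3 already sits at the limit recorded in the limit of > 40000 nM in this assay, at which 2 of the 3 values shown sit. The estimate implies a step that the limit leaves unreadable from compound 3 to compound 4, which is expected to be small, since compound 1 also gives > 40000 nM as a limit in this assay, and a number rather than a limit is expected only rarely for compound 4.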

Compound 4, half-maximal cytotoxic concentration: > 40000 nM
Compound 4 gave a limit, no number (the forecaster's own chance of this, stated with the estimate: 85%); the middle value is on the limit's open side.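

In this assay compound 4 gives > 40000 nM, a limit of the assay. With compound 3 also at a limit, no step can be read between compound 3 and compound 4: the limit of > 40000 nM in this assay, at which 3 of the 4 values shown sit.

The compounds shown leave open how far compound 1, compound 3 and compound 4 lie beyond that limit, and whether thiophen-2-yl in place of cyclohexyl changes the read-out on the core of compound 3 at all.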